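Dropping the Methoxy: One Step on a Bicyclic Nitrile

The source may report more compounds than this note shows. Statements on the series, on what has been measured and on what is new or still open speak of the compounds shown alone.

Measured so far in a functional assay on the whole organism (strain albino) for inhibition, with Rattus norvegicus as the target, read by paw edema, with stated times of 1 h and 2 h, at a dose of 20 mmol/kg by the intraperitoneal route; a higher number here means more inhibition at the dose given (going by the name of the read-out), a lower number less inhibition:
compound 1, `N#CC1=C(NCC(=O)O)N(c2ccccc2)C(=O)N2CCCCC(N3CCCC3)C12`, gives 81.7%
compound 2, `COc1ccc(N/C=N/C2=C(C#N)C3C(N4CCCC4)CCCCN3C(=O)N2c2ccccc2)cc1`, gives 37.2%

For the measured compounds named here, compound 2 stands at the lowest of these two numbers, and the only measured step leads down to it: a number 44.5 percentage points lower from compound 1 to compound 2 (beyond the scatter). That step swaps a whole side group at the double-bonded ring carbon and says little about a small edit on the aromatic ring.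

Compound 3, `N#CC1=C(/N=C/Nc2ccccc2)N(c2ccccc2)C(=O)N2CCCCC(N3CCCC3)C12`, is the next step: hydrogen in place of methoxy on an aromatic carbon. Going by the values given here, no measured pair shows the effect of losing a methoxy on this ring, so there is no direct precedent. Given that the core of compound 2 and its amidine linkage are kept, the expected step of a number 2.8 percentage points higher from compound 2 to compound 3 (within the scatter) is small and within the scatter, in no clear direction. Compound 3 is therefore estimated at 40%, with a range from 20% to 60%.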

Compound 3, a percentage reported as inhibition, in the whole organism at one dose (the size of the read-out at that dose, not a potency): 47.5%
For compound 3 the middle estimate is 7.5 percentage points below the measured one, within the range that was stated.
By their numbers in this assay, from the lowest: compound 2; then compound 3; then compound 1.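

In this assay, the edit from 4-methoxyphenyl to phenyl on the amidine side group has a measurable effect of its own, giving a number 10.3 percentage points higher from compound 2 to compound 3 (beyond the scatter), so this place on the aromatic ring is not silent. That gain is modest, however, and the exchange of the whole side group on the double-bonded ring carbon still leaves a number 34.2 percentage points lower from compound 1 to compound 3 (beyond the scatter), so removing the methoxy recovers only part of the distance to compound 1. Nothing measured here accounts for either step.

The compounds shown pair only methoxy and hydrogen at this place on the aromatic carbon, so the effect of a chlorine, a hydroxyl or an amine there remains open. As far as these compounds go, it is also open whether a carboxylic acid on this phenyl ring would bring the amidine series closer to compound 1.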